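Compound 4 in the tail flick series: carbamoyl for a five-atom chain

The source may report more compounds than this note shows. Statements on the series, on what has been measured and on what is new or still open speak of the compounds shown alone.

Compound 1 `N=C(N)NCCC[C@H](NC(=O)CN(c1ncnc2c1ncn2C1CCCCO1)C1CC1)C(=O)OCc1ccccc1` is tested in a functional assay on the whole organism (Tail, strain ICR) with Mus musculus as the target, in the tail flick test, with a stated time of 120 min, at a dose of 25 umol/kg by the oral route (on this read-out lower numbers stand for a weaker effect and higher numbers for a stronger effect at the one dose given), where compound 1 gives 38.2%. Compound 2 `C[C@@H](O)[C@H](NC(=O)CN(c1nc(Cl)nc2[nH]cnc12)C1CC1)C(=O)O` gives 37.6% and compound 3 `C[C@H](NC(=O)CN(c1nc(Cl)nc2[nH]cnc12)C1CC1)C(=O)O` gives 28.4% in this assay. Compound 1 stands highest of the three numbers, but both gaps are within the scatter: compound 2 lies nearest, compound 3 furthest. For the measured compounds named here, the one step measured between neighbours, a number 9.2 percentage points lower from compound 2 to compound 3 (within the scatter), exchanges a side chain directly on the saturated chain carbon that carries the amide-type nitrogen and the carbonyl carbon, on a core differing from that of compound 1.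

Compound 4 `NC(=O)CC[C@H](NC(=O)CN(c1ncnc2c1ncn2C1CCCCO1)C1CC1)C(=O)OCc1ccccc1` differs from compound 1 as follows: a group of 3 heavy atoms (1 carbon, 1 nitrogen, 1 oxygen; no ring) in place of a group of 5 heavy atoms (2 carbon, 3 nitrogen; no ring), on a saturated chain carbon, three bonds along the chain from an amide-type nitrogen and a carbonyl carbon. Going by the values given here, the change sits on a saturated chain carbon three bonds along the chain from the amide-type nitrogen and the carbonyl carbon, so the step from compound 2 to compound 3 touches a different place and a different core; it is the only comparable side-chain exchange and it stayed within the scatter. Among the compounds with values here, no measured step speaks for a shift beyond the scatter in this assay, and none is expected. The estimate for compound 4 is 34%, with a range from 20% to 48%. The expected step is a number 4.2 percentage points lower from compound 1 to compound 4 (within the scatter), within the scatter.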

Compound 4, a percentage reported as activity, at one dose (the size of the read-out at that dose, not a potency): 22.3%
Estimate against measurement, compound 4: 11.7 percentage points above; measured number inside the range.
By their numbers in this assay, from the lowest: compounds 4, 3, 2 and 1 (each within the scatter of the next, the first and the last beyond it).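

In this assay, for the compounds shown here, the saturated chain carbon, three bonds along the chain from an amide-type nitrogen and a carbonyl carbon, is the first place where an exchange of side chain gives a step beyond the scatter: carbamoyl in place of the group of 5 heavy atoms gives a number 15.9 percentage points lower from compound 1 to compound 4 (beyond the scatter) at the one dose and time tested. Going by these compounds alone, the only earlier step, a number 9.2 percentage points lower from compound 2 to compound 3 (within the scatter), lies at a different place on a different core, so the read-out on the shared core of compound 1 and compound 4 responds to a change that the earlier pair could not test. The exchange removes 3 hydrogen-bond donors and brings in 1, but no measurement at hand bears on why the number falls with this change.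

The compounds shown leave open how an amine, a carboxylic acid or a longer chain ending in carbamoyl would read in place of carbamoyl at this position on the core of compound 1. They also leave open whether the same exchange would give a step of similar size on the core of compound 2, or at other doses and times.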